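Sulfur substituent variation at the shared core of compound 1

The compounds below may be only part of what the source reports. "The series", "measured", "known", "first", "only" and "open" are said of these compounds alone.

Measured compounds:
compound 1 `CCCSc1nc2nc(C)cc(N3CC[C@@H](C)[C@@H](N(C)c4ncnc5[nH]ccc45)C3)n2n1`: 20900 nM
compound 2 `Cc1cc(N2CC[C@@H](C)[C@@H](N(C)c3ncnc4[nH]ccc34)C2)n2nc(SCc3ccc([N+](=O)[O-])cc3)nc2n1`: 29400 nM
compound 3 `Cc1cc(N2CC[C@@H](C)[C@@H](N(C)c3ncnc4[nH]ccc34)C2)n2nc(SCc3ccccc3)nc2n1`: 13900 nM

In a functional assay on HGC-27 cells (Homo sapiens) for inhibition, read by MTT assay, with a stated time of 72 h (a lower number here means a stronger inhibitor, a higher number a weaker inhibitor), compound 3 gives 13900 nM, the lowest number of the three, with compound 1 nearest at 20900 nM and compound 2 furthest at 29400 nM. Within the data shown here, only the step to compound 2 lies beyond the scatter: a 2.1-fold lower number from compound 2 to compound 3 (0.33 log units; beyond the scatter). The steps of a 1.4-fold higher number from compound 1 to compound 2 (0.15 log units; within the scatter) and a 1.5-fold lower number from compound 1 to compound 3 (0.18 log units; within the scatter) both stay within it.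

Compound 4 `C#CSc1nc2nc(C)cc(N3CC[C@@H](C)[C@@H](N(C)c4ncnc5[nH]ccc45)C3)n2n1` differs from compound 3 at the same sulfur: ethynyl in place of benzyl on a sulfur. Cut one bond further out, the difference reads benzylsulfanyl to ethynylsulfanyl. The three measured steps all concern the group on this sulfur, and none moved this assay more than modestly; the swap of ethyl for phenyl on the saturated chain carbon bound to the sulfur, a 1.5-fold lower number from compound 1 to compound 3 (0.18 log units; within the scatter), was within the scatter. Ethynyl in place of benzyl is a larger cut than any measured step, so the expectation is weaker, but there is no measured step pointing in either direction. For compound 4 a step within the scatter is expected, a 1.2-fold higher number from compound 3 to compound 4 (0.09 log units; within the scatter). Compound 4 is estimated at 17000 nM, within a range of 7000 nM to 42000 nM.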

Compound 4, half-maximal inhibitory concentration: 35100 nM
Compound 4: middle estimate off by 2.1-fold (0.31 log units), on the low side, within the range that was stated.
By their numbers in this assay, from the lowest: compounds 3, 1, 2 and 4 (each within the scatter of the next, the first and the last beyond it).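

In this assay, cutting benzyl back to ethynyl on the sulfur produces a step beyond the scatter (a 2.5-fold higher number from compound 3 to compound 4 (0.40 log units; beyond the scatter)), the largest separation in the set, so the group on this sulfur can shift the number even though the range stays narrow. Ethynyl does not separate from 4-nitrobenzyl (a 1.2-fold higher number from compound 2 to compound 4 (0.08 log units; within the scatter)) or from propyl (a 1.7-fold higher number from compound 1 to compound 4 (0.23 log units; within the scatter)), both steps being within the scatter, so the loss of the aromatic ring does not set the level on its own: compound 2 keeps that ring, compound 1 has none, and neither is separated from compound 4. No measurement available here explains why benzyl stands apart from ethynyl and 4-nitrobenzyl but not from propyl.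

The compounds shown leave open whether a longer alkyl chain, a terminal amine or a carboxylic acid on the sulfur would take the number outside this narrow band. Also open, going by these compounds, is whether a ring substituent other than nitro on the benzyl group would keep the level of compound 3 or lose it, as the 4-nitrobenzyl of compound 2 does.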